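Replacing a Fluorophenyl with Benzoxazole: Expected Liver Clearance

The source may hold more compounds than are shown below. What is called first, only, known or untested is meant among the compounds shown, and "the series" means these compounds.

Measured compounds:
compound 1 `COc1cc(C(O)(C(F)(F)F)C(F)(F)F)cnc1N1CCN(S(=O)(=O)c2ccc(N)nc2)CC1` — < 14 mL.min-1.g-1
compound 2 `CC(C)(O)C#Cc1cc(C(O)(C(F)(F)F)C(F)(F)F)cnc1N1CCN(S(=O)(=O)c2ccc(N)nc2)CC1` — < 14 mL.min-1.g-1
compound 3 `Nc1ccc(S(=O)(=O)N2CCN(c3ncc(C(O)(C(F)(F)F)C(F)(F)F)cc3-c3cccc(F)c3)CC2)cn1` — 25 mL.min-1.g-1

In an ADME assay (liver) for metabolic stability, with Liver microsome (Homo sapiens) as the target, using microsomes and NADPH, with a stated time of 30 min, tested at 1 uM (on this read-out lower numbers stand for slow clearance and higher numbers for fast clearance), compound 1 gives < 14 mL.min-1.g-1, which is a limit of the assay rather than a number. Compound 2 likewise sits at a limit, < 14 mL.min-1.g-1. Within the data shown here, compound 3 gives 25 mL.min-1.g-1, the only actual number among the three (the limit of < 14 mL.min-1.g-1 in this assay, at which 2 of the 3 values shown sit). The steps of an at least 1.7-fold higher number from compound 1 to compound 3 (0.25 log units; that floor lies within the scatter) and an at least 1.7-fold higher number from compound 2 to compound 3 (0.25 log units; that floor lies within the scatter) both lead to compound 3, and neither floor reaches beyond the scatter.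

Compound 4 `Nc1ccc(S(=O)(=O)N2CCN(c3ncc(C(O)(C(F)(F)F)C(F)(F)F)cc3-c3ccc4ocnc4c3)CC2)cn1` differs from compound 3 by 1,3-benzoxazol-5-yl in place of 3-fluorophenyl on an aromatic carbon. Among the measured compounds shown here, no measured step covers this exchange of one aromatic group for another, so the expectation is a step of a 1.3-fold lower number from compound 3 to compound 4 (0.10 log units; within the scatter), no larger than the scatter. Compound 4 is therefore estimated at 20 mL.min-1.g-1, within 10 mL.min-1.g-1 to 40 mL.min-1.g-1.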

Compound 4, intrinsic clearance in microsomes: < 14 mL.min-1.g-1
Compound 4 gave a limit, no number; the forecaster's own chance of this, stated with the estimate: 25%; middle value at least 1.4-fold (0.15 log units) away from the limit.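

Among the earlier compounds, only compound 3, the one with an aromatic group on this carbon, gave an actual number. The change to 1,3-benzoxazol-5-yl gives an at least 1.7-fold lower number from compound 3 to compound 4 (0.25 log units; that floor lies within the scatter), showing that an aromatic group at this position can also end at the limit in this assay: the limit of < 14 mL.min-1.g-1 in this assay, at which 3 of the 4 values shown sit. The steps from compound 1 and compound 2 to compound 4 cannot be read.

These limits leave methoxy, 3-hydroxy-3-methylbut-1-yn-1-yl and 1,3-benzoxazol-5-yl unranked. From the compounds shown here alone, whether an amine such as morpholine on this carbon would also stay at the limit remains open.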